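Swapping a Nitro for a Methyl: What to Expect

The source may hold more compounds than are shown below. What is called first, only, known or untested is meant among the compounds shown, and "the series" means these compounds.

Compound 1 `Brc1cccc(/C=C/c2nnc(-c3ccc4c(c3)OCCO4)o2)c1`: 13500 nM
Compound 2 `O=[N+]([O-])c1ccccc1/C=C/c1nnc(-c2ccc3c(c2)OCCO3)o1`: 25000 nM
Compound 3 `Clc1ccccc1/C=C/c1nnc(-c2ccc3c(c2)OCCO3)o1`: 7710 nM

In a functional assay on HUVEC cells (Homo sapiens) for antiproliferative activity, read by MTT assay, with a stated time of 48 h (a higher number here means a weaker inhibitor, a lower number a stronger inhibitor), compound 2 gives 25000 nM. Its separation from compound 1 lies within the scatter, while a 3.2-fold lower number from compound 2 to compound 3 (0.51 log units; beyond the scatter). Compound 4 `Cc1ccccc1/C=C/c1nnc(-c2ccc3c(c2)OCCO3)o1` differs from compound 2 by methyl in place of nitro on an aromatic carbon. The step that bears on it is the exchange of nitro for chloro at the same aromatic carbon, a 3.2-fold lower number from compound 2 to compound 3 (0.51 log units; beyond the scatter), since chloro and methyl are both single small groups with no hydrogen-bond acceptors. A modest fall in the number is therefore expected, a 2.5-fold lower number from compound 2 to compound 4 (0.40 log units; beyond the scatter). For compound 4 the estimated value in this assay is 10000 nM, with a range from 4000 nM to 25000 nM.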

Compound 4, half-maximal inhibitory concentration: 40500 nM
Compound 4: middle estimate off by 4.1-fold (0.61 log units), on the low side; the whole stated range lies below it.
By their numbers in this assay, from the lowest: compounds 3, 1, 2 and 4 (each within the scatter of the next, the first and the last beyond it).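

Chloro and methyl, though both single small groups, do not give the same result at this aromatic carbon in this assay (a 5.3-fold higher number from compound 3 to compound 4 (0.72 log units; beyond the scatter)), whereas methyl and nitro cannot be told apart (a 1.6-fold higher number from compound 2 to compound 4 (0.21 log units; within the scatter)). The 2-methylphenyl group also separates from the 3-bromophenyl group (a 3.0-fold higher number from compound 1 to compound 4 (0.48 log units; beyond the scatter)). Nothing available explains why methyl and chloro part so clearly.

The compounds shown leave open how an amine, a methoxy group or a longer chain would fare at this carbon. They also leave open whether the gap between chloro and methyl would persist on a different core.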